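Swapping the acetamido for trifluoromethyl on the shared core

The source may report more compounds than this note shows. Statements on the series, on what has been measured and on what is new or still open speak of the compounds shown alone.

Of the compounds shown here, three built on one shared core have been measured in an assay on HEK293 cells for binding affinity to Neuronal acetylcholine receptor; alpha4/beta2 (Homo sapiens); a lower number here means a stronger inhibitor, a higher number a weaker inhibitor. Compound 1 `CC(=O)c1ccc2c(c1)C1CNCC2C1` gives 0.17 nM, compound 3 `Cc1noc2cc3c(cc12)C1CNCC3C1` gives 0.13 nM, and compound 2 `CC(=O)Nc1ccc2c(c1)C1CNCC2C1` gives 75 nM. Compound 2 thus holds the highest number of the three, standing well apart from both compound 1 and compound 3.

Compound 4 `FC(F)(F)c1ccc2c(c1)C1CNCC2C1` has not yet been measured. The change leading to it is trifluoromethyl in place of acetamido on an aromatic carbon. Among the compounds with values here, only one measured step touches this position: a 440-fold higher number from compound 1 to compound 2 (2.64 log units; beyond the scatter), a large rise on going from acetyl to acetamido. Within the data shown here, the step to compound 4 removes that acetamido again, so a large fall in this assay is expected, though there is no measured step telling how trifluoromethyl compares with acetyl, so a return all the way to the number of compound 1 is uncertain.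

For compound 4 the estimate is 2 nM, within a range of 0.3 nM to 15 nM, which would mean an expected step of a 38-fold lower number from compound 2 to compound 4 (1.57 log units; beyond the scatter).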

Compound 4, inhibition constant: 0.33 nM
Compound 4: the middle estimate sits 6.1-fold (0.78 log units) above what was measured, within the range that was stated.
By their numbers in this assay, from the lowest: compounds 3, 1 and 4 (each within the scatter of the next, the first and the last beyond it); then compound 2.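

In this assay the new result gives a second reading at this aromatic carbon: trifluoromethyl in place of acetamido brings a 230-fold lower number from compound 2 to compound 4 (2.36 log units; beyond the scatter) and so undoes nearly all of the rise seen with acetamido. Trifluoromethyl in place of acetyl gives a 1.9-fold higher number from compound 1 to compound 4 (0.29 log units; within the scatter) so these two quite different groups cannot be told apart here, and among compounds 1, 2 and 4 only compound 2, with its acetamido, stands apart. Nothing measured here explains why acetamido behaves so differently, and this swap changes several features at once, including the hydrogen-bond donor and acceptor counts.

Still open, as far as these compounds go, is how other groups on this carbon would compare, such as a simple amine, a carboxylic acid or a longer alkyl chain. From the compounds shown here alone, it is also open whether a larger amide would stand as far from compound 1 as acetamido does.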